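A few compounds are considered here, and "the series" means these few. Any claim that something is new, unique, unknown or untested is made for them only; others in the source may bear on it.

Measured so far:
- compound 1, `CC(C)c1c(C(=O)N(C)Cc2cccc(F)c2)nn(-c2ccc(F)cc2)c1CC[C@@H](O)C[C@@H](O)CC(=O)O`: 1900 nM
- compound 2, `CCN(Cc1ccccc1)C(=O)c1nn(-c2ccc(F)cc2)c(OC[C@@H](O)C[C@@H](O)CC(=O)O)c1C(C)C`: 2660 nM

Both compounds share one core; compound 1 carries a two-carbon link to the dihydroxy acid chain and compound 2 an oxygen link. In a functional assay on L6 cells (Rattus norvegicus) for inhibition (on this read-out lower numbers stand for stronger inhibition and higher numbers for weaker inhibition), compound 1 gives 1900 nM and compound 2 gives 2660 nM. Compound 2 stands at the higher of the two numbers, but its gap to compound 1 lies within the scatter, so the two read as equivalent on this assay; no ordering is claimed between them.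

Compound 3, `CC(C)c1c(C(=O)N2CCCC2c2ccccc2)nn(-c2ccc(F)cc2)c1OC[C@@H](O)C[C@@H](O)CC(=O)O`, has not been measured. It differs from compound 2 in one place:

2-phenylpyrrolidin-1-yl in place of benzyl(ethyl)amino on a carbonyl carbon

The benzyl(ethyl)amino group is thus replaced by a 2-phenylpyrrolidin-1-yl group on the carbonyl carbon, the rest of the molecule kept. For the measured compounds named here, no measured pair shows the effect of such a change, so there is no basis for expecting a step beyond the scatter in either direction. The expected step from compound 2 to compound 3 is therefore small, a 1.1-fold lower number from compound 2 to compound 3 (0.03 log units; within the scatter), with wide uncertainty. Compound 3 is estimated at 2500 nM in this assay, in the range 800 nM to 8000 nM.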

Compound 3, half-maximal inhibitory concentration: 4340 nM
The estimate for compound 3 lay 1.7-fold (0.24 log units) below the measured number, within the range that was stated.
By their numbers in this assay, from the lowest: compounds 1, 2 and 3 (each within the scatter of the next, the first and the last beyond it).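

At the carbonyl carbon of the oxygen-linked series, replacing benzyl(ethyl)amino with 2-phenylpyrrolidin-1-yl gives in this assay a 1.6-fold higher number from compound 2 to compound 3 (0.21 log units; within the scatter) and so does not separate the two compounds on this read-out. This is the first step shown at this position: the open amine with its ethyl and benzyl arms gives way to a five-membered non-aromatic ring, with the six-membered aromatic ring retained and one heavy atom added, and the result stays within the scatter. No measurement bears on why this change leaves the read-out within the scatter.

From the compounds shown here alone, this single pair defines no trend at the carbonyl carbon, and whether pyrrolidin-1-yl without the phenyl group, piperidin-1-yl or dibenzylamino in the same place would give a step beyond the scatter remains open. Also open, going by these compounds, is whether 2-phenylpyrrolidin-1-yl would behave in the same way on the shared core with the two-carbon link of compound 1 in place of the oxygen link.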